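Thiazolidinone hydrazones: thiophene for pyridine on the imine carbon

The source may hold more compounds than are shown below. What is called first, only, known or untested is meant among the compounds shown, and "the series" means these compounds.

Three compounds of the shared core have numbers in an ADME assay on HEp-2 cells (Homo sapiens) for cytotoxicity, read by trypan blue exclusion, with a stated time of 24 h; on this read-out lower numbers stand for higher toxicity in this test and higher numbers for lower toxicity in this test. Compound 1 `C/C(=N\N=C1/SCC(=O)N1Cc1cccc(F)c1)c1cccs1` gives 6 ug/mL. Compound 2 `O=C1CS/C(=N\N=C2CCCC2)N1Cc1ccc(Cl)cc1` gives 16 ug/mL. Compound 3 `C/C(=N\N=C1/SCC(=O)N1Cc1cccc(Cl)c1)c1ccccn1` gives 21 ug/mL, the highest of the three numbers; the gap to compound 2 lies within the scatter, while the gap to compound 1 lies beyond it, so only against compound 1 does compound 3 show clearly lower toxicity in this assay.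

The step under consideration goes from compound 3 to compound 4 `C/C(=N\N=C1/SCC(=O)N1Cc1cccc(Cl)c1)c1cccs1`. The change is thiophen-2-yl in place of pyridin-2-yl on a carbon with a double bond to nitrogen. Among the compounds with values here, no pair of measured compounds differs in one place, so the size of this step has no direct precedent. Compound 1, which carries the thiophen-2-yl group, sits well below compound 3, which supports an expectation that the step from compound 3 to compound 4 will lower the number, by an amount around a 2.1-fold lower number from compound 3 to compound 4 (0.32 log units; beyond the scatter). Compound 4 is therefore expected to give about 10 ug/mL, with a range from 4 ug/mL to 25 ug/mL.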

Compound 4, half-maximal cytotoxic concentration in the HEp-2 assay: 21 ug/mL
For compound 4 the middle estimate is 2.1-fold (0.32 log units) below the measured one, and the stated range covers the measured number.
By their numbers in the HEp-2 assay, from the lowest: compound 1; then compounds 2, 3 and 4 (each within the scatter of the next).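

In the HEp-2 assay, thiophen-2-yl in place of pyridin-2-yl on a carbon with a double bond to nitrogen gives no change at the digits printed from compound 3 to compound 4 (within the scatter), so this ring exchange does not separate the two compounds on this read-out. With thiophen-2-yl held constant, chloro in place of fluoro on an aromatic carbon in the HEp-2 assay gives a 3.5-fold higher number from compound 1 to compound 4 (0.54 log units; beyond the scatter), which places the clear difference in this pair at the halogen. In a physicochemical assay, with a stated time of 90 min (a lower number here means that less compound is needed, a higher number that more compound is needed for the effect), compound 3 gives 2040000 nM and compound 4 gives 1160000 nM, with a 1.8-fold lower number from compound 3 to compound 4 (0.25 log units; within the scatter), so the ring exchange stays within the scatter on this read-out as well.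

Nothing available explains either step. From the compounds shown here alone, it remains open whether the halogen step recurs with pyridin-2-yl in place, and whether phenyl or an amine-bearing ring on the same carbon would also leave these numbers unchanged.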